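A cyano-bearing amide opened toward an acid-ester side chain

This account rests on a few compounds, and the source may have more. Where it says the series, first, only, none or still open, it means among the compounds named here.

Compound 1 `CCn1c(C(=O)NCC#N)ccc1C(CC)(CC)c1ccc(OCCC(O)(CC)CC)c(C)c1` carries a cyanomethyl group on the amide nitrogen of the shared core. In an ADME assay on L02 cells (Homo sapiens) for antiproliferative activity, read by MTT assay, with a stated time of 48 h (a higher number here means a weaker inhibitor, a lower number a stronger inhibitor), compound 1 reaches only a limit of the assay, > 50000 nM. Compound 2 `CCn1c(C(=O)Nc2ccc(OC(F)(F)F)cc2)ccc1C(CC)(CC)c1ccc(OCCC(O)(CC)CC)c(C)c1` likewise gives only a limit, > 50000 nM. Compound 3 `CCOC(=O)CN(C)C(=O)c1ccc(C(CC)(CC)c2ccc(OCCC(O)(CC)CC)c(C)c2)n1CC` gives 1990 nM; hence an at least 25-fold lower number from compound 1 to compound 3 (1.40 log units; beyond the scatter) and an at least 25-fold lower number from compound 2 to compound 3 (1.40 log units; beyond the scatter), whereas a step that the two limits leave unreadable from compound 1 to compound 2. Compound 4 `CCn1c(C(=O)NC(CC(=O)O)C(=O)OC)ccc1C(CC)(CC)c1ccc(OCCC(O)(CC)CC)c(C)c1` is not yet measured and differs from compound 1 in that (a group of 9 heavy atoms (5 carbon, 4 oxygen; no ring) in place of a group of 3 heavy atoms (2 carbon, 1 nitrogen; no ring), on an amide-type nitrogen). Among the measured compounds shown here, the one earlier change on the amide-type nitrogen was unreadable, and the readable steps concern a different kind of change on the carbonyl carbon; both recorded amide-nitrogen variants sit at the limit of > 50000 nM in this assay, at which 2 of the 3 values shown sit. The expected step is therefore a step that the limit leaves unreadable from compound 1 to compound 4, and compound 4 is estimated at 60000 nM in this assay, within 15000 nM to 200000 nM, most likely again as a limit.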

Compound 4, half-maximal inhibitory concentration: 7590 nM
Compound 4: the middle estimate sits 7.9-fold (0.90 log units) above what was measured, and the stated range ends above it.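

In this assay the amide-type nitrogen now gives readable steps, an at least 6.5-fold lower number from compound 1 to compound 4 (0.81 log units; beyond the scatter) and an at least 6.5-fold lower number from compound 2 to compound 4 (0.81 log units; beyond the scatter), with the 9-heavy-atom group in place of cyanomethyl or 4-(trifluoromethoxy)phenyl. A change at this position can therefore leave the limit of the assay: the limit of > 50000 nM in this assay, at which 2 of the 4 values shown sit. Even so, the side chain of compound 3 on the carbonyl carbon keeps the lower number, with a 3.8-fold higher number from compound 3 to compound 4 (0.58 log units; beyond the scatter).

On these data alone, whether the carboxylic acid or the methyl ester of the entering group carries the step stays open, since compound 4 holds both. As far as these compounds go, how a simple amine or a longer alkyl chain on this nitrogen would read also stays open.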